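A few compounds are considered here, and "the series" means these few. Any claim that something is new, unique, unknown or untested is made for them only; others in the source may bear on it.

Compound 1, `CCCCCCCOc1c(-c2cc(OC)c(OC)c(OC)c2)oc2ccccc2c1=O`: in a functional assay on DU-145 cells (Homo sapiens) for antiproliferative activity, read by WST assay, with a stated time of 3 days (on this read-out higher numbers stand for weaker inhibition and lower numbers for stronger inhibition), compound 1 gives > 50000 nM, which is a limit of the assay and not a number.
Compound 2, `CCN(CC)CCCOc1c(-c2cc(OC)c(OC)c(OC)c2)oc2ccccc2c1=O`: compound 2 gives > 50000 nM, again only a limit.
Compound 3, `CCCCN(CCCC)CCCCOc1c(-c2cc(OC)c(OC)c(OC)c2)oc2ccccc2c1=O`: compound 3 gives 15300 nM.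

Compound 1 thus sits at the limit of > 50000 nM in this assay, at which 2 of the 3 values shown sit, so only a limit is known for it. Compound 4, `CCCCCN(CCCCC)CCCOc1c(-c2cc(OC)c(OC)c(OC)c2)oc2ccccc2c1=O`, differs from compound 1 by dipentylamino in place of butyl on a saturated chain carbon, three bonds along the chain from an oxygen on an aromatic ring. Among the measured compounds shown here, one measured step bears on this: an at least 3.2-fold lower number from compound 1 to compound 3 (0.51 log units; beyond the scatter). The other, a step that the two limits leave unreadable from compound 1 to compound 2, is uninformative, though compound 2 carries a smaller amine on the same chain length as compound 4. Because of an at least 3.2-fold lower number from compound 1 to compound 3 (0.51 log units; beyond the scatter), a drop of at least modest size is expected for compound 4, an at least 3.3-fold lower number from compound 1 to compound 4 (0.52 log units; beyond the scatter). Compound 4 is therefore estimated at 15000 nM, within 5000 nM to 50000 nM.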

Compound 4, half-maximal inhibitory concentration: 12300 nM
Estimate against measurement, compound 4: 1.2-fold (0.09 log units) above; the range from low to high includes it.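

Replacing butyl with dipentylamino gives an at least 4.0-fold lower number from compound 1 to compound 4 (0.60 log units; beyond the scatter), and replacing diethylamino with the same group gives an at least 4.0-fold lower number from compound 2 to compound 4 (0.60 log units; beyond the scatter); both sizes are only minimums, set by the limit: the limit of > 50000 nM in this assay, at which 2 of the 4 values shown sit. At this place, then, dipentylamino gives a measurable number where diethylamino does not, so the alkyl groups on the amine matter and not just the presence of an amine. The two larger amines cannot be separated, as the comparison gives a 1.2-fold lower number from compound 3 to compound 4 (0.09 log units; within the scatter).

As far as these compounds go, whether a larger amine such as dihexylamino, or a ring amine such as piperidine, would lower the number further remains open.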